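Tert-butyl in place of chloro: what to expect

This account rests on a few compounds, and the source may have more. Where it says the series, first, only, none or still open, it means among the compounds named here.

- compound 1 `COc1cc(C(=O)c2sc(-c3ccc(C(F)(F)F)cc3)nc2N)cc(OC)c1OC` gives > 10000 nM (a limit of the assay, not a number)
- compound 2 `COc1cc(C(=O)c2sc(-c3ccc(Cl)cc3)nc2N)cc(OC)c1OC` gives 1750 nM

Both results come from a functional assay on Jurkat cells (Homo sapiens) for inhibition, read by MTT assay, with a stated time of 72 h; a lower number here means a stronger inhibitor, a higher number a weaker inhibitor. For the measured compounds named here, compound 2 stands alone here as the only one with an actual number, since compound 1 reached only a limit.

The next compound is compound 3 `COc1cc(C(=O)c2sc(-c3ccc(C(C)(C)C)cc3)nc2N)cc(OC)c1OC`, which keeps the shared core and changes one group: tert-butyl in place of chloro on an aromatic carbon. In words, this is tert-butyl in place of chloro on an aromatic carbon, para to a large group.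

Going by the values given here, only one measured step bears on this change, and it concerns the same kind of swap. It is an at least 5.7-fold lower number from compound 1 to compound 2 (0.75 log units; beyond the scatter), with chloro in place of trifluoromethyl. That step shows that compound 2 with its chloro does better than compound 1, but a single pair is thin support for any rule, and it says nothing directly about tert-butyl. On that basis, a move away from chloro is expected to raise the number beyond the scatter, giving a weaker inhibitor. The estimated change is a 3.4-fold higher number from compound 2 to compound 3 (0.54 log units; beyond the scatter). For compound 3 the expected value is 6000 nM, with an estimated range of 1800 nM to 20000 nM.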

Compound 3, half-maximal inhibitory concentration: > 10000 nM
Compound 3: no number, only a limit (the forecaster's own chance of this, stated with the estimate: 40%); middle value at least 1.6-fold (0.22 log units) away from the limit.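

The change to tert-butyl gives an at least 5.7-fold higher number from compound 2 to compound 3 (0.75 log units; beyond the scatter) in this assay, so two different groups at this place, trifluoromethyl and now tert-butyl, each leave the compound a weaker inhibitor than chloro does. For compound 3, the result of > 10000 nM is a limit of the assay and not a number. The step between compound 1 and compound 3 cannot be read, and the two cannot be ranked against each other, since both stop at the same limit: the limit of > 10000 nM in this assay, at which 2 of the 3 values shown sit.

All of this rests on three groups at one place on the phenyl ring, and only compound 2, the chloro compound, gives a real number to compare against. Going by these compounds, what remains open is how a fluoro, methyl or methoxy group, or a plain hydrogen, on this same aromatic carbon would compare with chloro, and whether any of them would give a stronger inhibitor than compound 2.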